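Aryl Substituent Exchange on the Shared Core

A few compounds are considered here, and "the series" means these few. Any claim that something is new, unique, unknown or untested is made for them only; others in the source may bear on it.

Compound 1 `COC(=O)C1=C(C)N=C(C)N(CCCCCN2CCC(c3ccccc3C(F)(F)F)CC2)C1c1ccc(F)c(F)c1` sets the starting point: in an assay on isolated protein for binding affinity to Alpha-1A adrenergic receptor (Homo sapiens) (on this read-out higher numbers stand for weaker inhibition and lower numbers for stronger inhibition), compound 1 gives 1.1 nM. Compound 2 `COC(=O)C1=C(C)N=C(C)N(CCCCCN2CCC(c3ccccc3OC)CC2)C1c1ccc(F)c(F)c1` gives 0.3 nM in this assay, and the single-point exchange reads a 3.7-fold lower number from compound 1 to compound 2 (0.56 log units; beyond the scatter). Compound 3 `COC(=O)C1=C(C)N=C(C)N(CCCCCN2CCN(c3ccccc3OC)CC2)C1c1ccc(F)c(F)c1` gives 0.4 nM in this assay. Compound 3 thus holds the second highest of the three numbers: its gap to compound 2 lies within the scatter, whereas compound 1 gives a number beyond the scatter above it.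

Compound 4 `COC(=O)C1=C(C)N=C(C)N(CCCCCN2CCN(c3ccccc3C(=O)OC)CC2)C1c1ccc(F)c(F)c1` is not yet measured. Against compound 3 the change is methoxycarbonyl in place of methoxy on an aromatic carbon. Among the measured compounds shown here, no measured step covers this exchange. For the measured compounds named here, the only step in the set, a 3.7-fold lower number from compound 1 to compound 2 (0.56 log units; beyond the scatter), concerns a different pair of groups on the aromatic carbon of a compound without the change that separates compound 2 from compound 3, so it shows only that this aromatic carbon can move the number by a modest amount. For compound 4 a modest step is therefore expected, a 2.0-fold higher number from compound 3 to compound 4 (0.30 log units; within the scatter), with direction uncertain. In this assay compound 4 is estimated at 0.8 nM, within 0.25 nM to 3 nM.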

Compound 4, inhibition constant: 0.5 nM
The estimate for compound 4 lay 1.6-fold (0.20 log units) above the measured number; the range from low to high includes it.
By their numbers in this assay, from the lowest: compounds 2, 3 and 4 (each within the scatter of the next); then compound 1.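

In this assay, the exchange from 2-methoxyphenyl to 2-(methoxycarbonyl)phenyl reads a 1.3-fold higher number from compound 3 to compound 4 (0.10 log units; within the scatter), so on this aromatic carbon, ortho to a large group, the larger methoxycarbonyl with its extra hydrogen-bond acceptor cannot be told apart from methoxy. The earlier step at this carbon, a 3.7-fold lower number from compound 1 to compound 2 (0.56 log units; beyond the scatter), lay beyond the scatter, so the new pair shows that an exchange here need not move the number that far, although the two steps stand on different compounds. Nothing at hand offers an explanation for this flat step.

The compounds shown leave open whether a carboxylic acid or a primary amide in place of methoxycarbonyl would stay within the scatter of compound 4. They also leave open whether an amine on this aromatic carbon would do the same.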